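Swapping a phenethyl for a 4-ethylphenyl on the sulfur

A few compounds are considered here, and "the series" means these few. Any claim that something is new, unique, unknown or untested is made for them only; others in the source may bear on it.

Of the compounds shown here, three sharing one core have been tested in a functional assay on SMMC-7721 cells (Homo sapiens) for inhibition, read by CCK-8 assay, with a stated time of 72 h, tested at 2 uM; on this read-out lower numbers stand for less inhibition of growth and higher numbers for more inhibition of growth at the one concentration tested. Compound 1 `Nc1ccccc1NC(=O)/C=C/c1ccc(CSc2ccc(F)cc2)cc1` gives 18.3%, compound 2 `Nc1ccccc1NC(=O)/C=C/c1ccc(CSc2cccc(F)c2)cc1` gives 8.56%, and compound 3 `Nc1ccccc1NC(=O)/C=C/c1ccc(CSCCc2ccccc2)cc1` gives 14.7%. Compound 3 is separated from compound 1 by a number 3.6 percentage points lower from compound 1 to compound 3 (within the scatter) and from compound 2 by a number 6.1 percentage points higher from compound 2 to compound 3 (within the scatter), so all three numbers sit within the usual scatter of one another, and none of them can be called more or less active than another on this evidence.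

Compound 4 `CCc1ccc(SCc2ccc(/C=C/C(=O)Nc3ccccc3N)cc2)cc1` has not yet been measured. Its structure differs from compound 3 in one place: 4-ethylphenyl in place of phenethyl on a sulfur. Both steps that already exist, from compound 1 to compound 3 and from compound 2 to compound 3, exchanged a fluorophenyl for a phenethyl on the same sulfur, and each stayed within the scatter. Within the data shown here, the new change once more swaps one eight-carbon group for another on that sulfur, and nothing among the measured compounds suggests a larger effect. The expected step is therefore a number 0.3 percentage points higher from compound 3 to compound 4 (within the scatter), meaning no change beyond the scatter. Compound 4 is estimated to give 15% in this assay, with a likely range from 6% to 26%.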

Compound 4, percent growth inhibition at one concentration: 13.2%
Beside the measured number, compound 4's estimate is 1.8 percentage points above it; the measured number falls inside the stated range.
By their numbers in this assay, from the lowest: compounds 2, 4, 3 and 1 (each within the scatter of the next).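

In this assay, among these compounds, the phenethyl and the 4-ethylphenyl are made of the same atoms joined differently, and exchanging them on a sulfur whose other neighbour is a saturated chain carbon gives a number 1.5 percentage points lower from compound 3 to compound 4 (within the scatter), so this rearrangement produces no step that can be told from the scatter. Among the compounds shown here, until now the only aromatic groups placed directly on this sulfur carried fluoro, and an ethyl in that role adds two more steps within the scatter: a number 5.1 percentage points lower from compound 1 to compound 4 (within the scatter) and a number 4.6 percentage points higher from compound 2 to compound 4 (within the scatter), which means none of the four groups at this position can be ranked above another on these numbers. No supporting measurement is available to explain these results.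

From the compounds shown here alone, it remains open whether an amine or a carboxylic acid on the aromatic ring, or a chain longer than phenethyl on the sulfur, would give a step beyond the scatter. Going by these compounds, it is also open whether these four compounds would separate from one another at a higher concentration, or in a full dose-response series.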